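Removing the methyl from compound 2: working notes

The source may hold more compounds than are shown below. What is called first, only, known or untested is meant among the compounds shown, and "the series" means these compounds.

In a functional assay on Hs 683 cells (Homo sapiens) for cytotoxicity, read by MTT assay, with a stated time of 72 h (a lower number here means a stronger inhibitor, a higher number a weaker inhibitor), the series stands as follows:
- compound 1 `c1ccc2[nH]c(-n3cccn3)cc2c1` gives > 100000 nM (a limit of the assay, not a number)
- compound 2 `Cc1ccc2[nH]c(-n3cccn3)c(C3=C(Br)C(=O)NC3=O)c2c1` gives 29000 nM
- compound 3 `COc1ccc2[nH]c3c(c4c(c5ccnn53)C(=O)NC4=O)c2c1` gives 22000 nM

Going by the values given here, compound 2, at 29000 nM in this assay, lies within the scatter of compound 3, at 22000 nM, and these are the only two numbers. Compound 1 reports only a limit.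

Compound 4 `O=C1NC(=O)C(c2c(-n3cccn3)[nH]c3ccccc23)=C1Br` is still to be measured. It differs from compound 2 by hydrogen in place of methyl on an aromatic carbon and this carbon belongs to a six-membered aromatic ring of carbon only, part of a fused or bridged system of two rings. Among the compounds with values here, no measured pair isolates this change, so the data give no direct size for such a step in this assay. The expectation therefore rests on compound 2 at 29000 nM and no step beyond the scatter is expected in either direction. The expected step, a 1.0-fold higher number from compound 2 to compound 4 (0.01 log units; within the scatter), is an estimate only. A limit in place of a number remains possible for compound 4. Compound 4 is estimated at 30000 nM (expected range 12000 nM to 80000 nM).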

Compound 4, half-maximal inhibitory concentration: 29000 nM
The estimate for compound 4 lay 1.0-fold (0.01 log units) above the measured number, within the range that was stated.
By their numbers in this assay, from the lowest: compounds 3, 2 and 4 (each within the scatter of the next). At a limit, above all of these: compound 1.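

In this assay, hydrogen in place of methyl on an aromatic carbon gives no change at the digits printed from compound 2 to compound 4 (within the scatter). Going by these compounds alone, this is the first step that isolates a single group at this position, as no earlier pair of measured compounds differed in one place only. It shows that, on this scaffold and in this assay, the methyl is not needed for the reading of compound 2: the unsubstituted carbon of compound 4 serves equally well, which makes compound 4 the simpler reference for further work at this position.

As far as these compounds go, whether this position tolerates every group remains open, as one small group says nothing about an amine, a carboxylic acid or a longer chain on the same aromatic carbon, nor about whether the same swap would behave alike on a different core. Compound 1 gives a limit and not a number, so no step involving it can be read: the limit of > 100000 nM in this assay, at which 1 of the 4 values shown sits.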